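A few compounds are considered here, and "the series" means these few. Any claim that something is new, unique, unknown or untested is made for them only; others in the source may bear on it.

Compound 2 `CCOC(=O)C1=Cc2ccccc2OC1(OCc1cn(-c2ccc(C)cc2)nn1)C(F)(F)F` stands at the high end of the two numbers in hand: in a functional assay on HeLa cells (Homo sapiens) for inhibition, read by MTT assay, with a stated time of 24 h (a higher number here means a weaker inhibitor, a lower number a stronger inhibitor), compound 2 gives 25100 nM, whereas compound 3 `CCOC(=O)C1=Cc2ccccc2OC1(OCc1cc(-c2ccc(Cl)cc2)no1)C(F)(F)F` gives 12300 nM. Compound 1 `CCOC(=O)C1=Cc2ccccc2OC1(OCc1cc(-c2ccc(OC)cc2)no1)C(F)(F)F` gives only a limit of this assay, > 150000 nM; this is the limit of > 150000 nM in this assay, at which 1 of the 3 values shown sits. Within the data shown here, the single one-place step measured so far is an at least 12-fold lower number from compound 1 to compound 3 (1.08 log units; beyond the scatter). Compound 4 `CCOC(=O)C1=Cc2ccccc2OC1(OCc1cn(-c2cccc(OC)c2)nn1)C(F)(F)F` differs from compound 2 by 3-methoxyphenyl in place of 4-methylphenyl on an aromatic nitrogen. That measured step sits on a different five-membered ring and a different place of the phenyl ring, so it bears on the present change only loosely; it does put a methoxy compound at the weak end. For compound 4 a step of a 2.0-fold higher number from compound 2 to compound 4 (0.30 log units; within the scatter) towards a higher number is therefore expected, modest in size. The estimate for compound 4 is 50000 nM, with a range from 15000 nM to 200000 nM.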

Compound 4, half-maximal inhibitory concentration: > 150000 nM
Compound 4: a limit, no number; the forecaster's own chance of this, stated with the estimate: 25%; middle value at least 3.0-fold (0.47 log units) away from the limit.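

On the aromatic nitrogen, the aryl group is not a free choice in this assay: 3-methoxyphenyl in place of 4-methylphenyl gives an at least 5.9-fold higher number from compound 2 to compound 4 (0.77 log units; beyond the scatter). Among these compounds, this is the first step measured on this nitrogen, and its true size stays open at the upper end. Compound 4 gives a limit and not a number, the second such value in the set: the limit of > 150000 nM in this assay, at which 2 of the 4 values shown sit.

The change alters both the substituent and its place on the phenyl ring, so the two cannot be separated here. A 3-methylphenyl group on this nitrogen would separate them, and a 4-carboxyphenyl group would test a carboxylic acid there.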